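This account rests on a few compounds, and the source may have more. Where it says the series, first, only, none or still open, it means among the compounds named here.

Compound 1 `CC(Nc1nc(N)nc2ccn(Cc3ccccn3)c12)c1ccccn1`, compound 2 `Nc1nc(NCc2ncco2)c2c(ccn2Cc2ccccn2)n1` and compound 3 `CC(C)c1cc(CNc2nc(N)nc3ccn(Cc4ccccn4)c23)no1` share one core and differ only in the group on a nitrogen on an aromatic ring. In an ADME assay on HEK293 cells (Homo sapiens) for cytotoxicity, read by ATP content, with a stated time of 6 h (on this read-out lower numbers stand for higher toxicity in this test and higher numbers for lower toxicity in this test), compound 1 gives > 24000 nM, which is a limit of the test rather than a number. In this assay compound 2 likewise gives > 24000 nM, again a limit. Compound 3 gives > 24000 nM, also a limit. The steps a step that the two limits leave unreadable from compound 1 to compound 2, a step that the two limits leave unreadable from compound 1 to compound 3 and a step that the two limits leave unreadable from compound 2 to compound 3 cannot be sized because of the limit of > 24000 nM in this assay, at which 3 of the 3 values shown sit. Compound 4 `Cc1nc(COc2nc(N)nc3ccn(Cc4ccccn4)c23)no1` differs from compound 2 by (5-methyl-1,2,4-oxadiazol-3-yl)methoxy in place of ((1,3-oxazol-2-yl)methyl)amino on an aromatic carbon. Among the measured compounds shown here, no measured step bears readably on this change, so no step beyond the scatter is expected. Compound 4 is expected to give 30000 nM, between 15000 nM and 100000 nM. The expected step is a step that the limit leaves unreadable from compound 2 to compound 4.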

Compound 4, half-maximal cytotoxic concentration: > 24000 nM
Compound 4 gave a limit, no number; the forecaster's own chance of this, stated with the estimate: 85%; the middle value does not contradict the limit.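

No new step can be read from compound 2 to compound 4, because both values are limits and not numbers: the limit of > 24000 nM in this assay, at which 4 of the 4 values shown sit. The compounds shown leave open whether the groups on the shared core differ at all in this assay.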